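This account rests on a few compounds, and the source may have more. Where it says the series, first, only, none or still open, it means among the compounds named here.

Of the compounds shown here, three have been measured in an assay on CHO cells for displacement of a labelled ligand from prostaglandin E2 receptor EP3 subtype (Homo sapiens), read by radioligand binding; on this read-out higher numbers stand for weaker inhibition and lower numbers for stronger inhibition. Compound 1 `CCn1ncc2c(F)cc(-c3ccc(C(CC)(CC)c4nnc(C)[nH]4)c(=O)[nH]3)cc21` gives 34 nM, compound 2 `CC(C)C(c1ccc(-c2ccc3cccc(F)c3c2)[nH]c1=O)N1CCNC1=O` gives 9.1 nM, and compound 3 `CCn1ncc2c(C)cc(-c3ccc([C@@]4(C)CCNC4=O)c(=O)[nH]3)cc21` gives 5 nM. Compound 2 thus holds the second highest of the three numbers; its distance to compound 3 lies within the usual scatter, while compound 1 sits beyond it with a clearly higher number.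

Compound 4 `CC(C)C(Nc1nnc[nH]1)c1ccc(-c2ccc3cccc(F)c3c2)[nH]c1=O` differs from compound 2 in one place: (4H-1,2,4-triazol-3-yl)amino in place of 2-oxoimidazolidin-1-yl on a saturated chain carbon bound to an aromatic carbon and a saturated chain carbon. Among the measured compounds shown here, no measured pair shows this change, so the expectation rests on the spread already seen. A step from compound 2 of modest size toward a weaker result, a 2.0-fold higher number from compound 2 to compound 4 (0.30 log units; within the scatter), is expected, since compound 1 reached only 34 nM. Compound 4 is therefore estimated at 18 nM, within 5 nM to 60 nM.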

Compound 4, inhibition constant: 22 nM
Compound 4: middle estimate off by 1.2-fold (0.09 log units), on the low side; measured number inside the range.
By their numbers in this assay, from the lowest: compounds 3 and 2 (each within the scatter of the next); then compounds 4 and 1 (each within the scatter of the next).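

In this assay, replacing 2-oxoimidazolidin-1-yl with (4H-1,2,4-triazol-3-yl)amino on this saturated chain carbon gives a 2.4-fold higher number from compound 2 to compound 4 (0.38 log units; beyond the scatter) and so changes the result measurably, though only modestly. The place therefore accepts either a non-aromatic ring or an aromatic ring carried through an amino link, with both groups having the same heavy-atom count, and binding remains in the nanomolar range. No measurement here explains the difference.

As far as these compounds go, whether a plain amine or a carboxylic acid on this carbon would give a lower or higher number remains open. So does whether the same replacement would have a similar effect on a different core.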